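A few compounds are considered here, and "the series" means these few. Any claim that something is new, unique, unknown or untested is made for them only; others in the source may bear on it.

For the measured compounds named here, compound 2 `Cc1cc(Br)cc(Br)c1Oc1nc(Nc2ccc(C#N)cc2)nc2ccccc12` gives the higher of the two numbers so far in an ADME assay on MT4 cells (Homo sapiens) for cytotoxicity, read by MTT assay, with a stated time of 4 days; on this read-out lower numbers stand for higher toxicity in this test and higher numbers for lower toxicity in this test: compound 2 gives 150000 nM, while compound 1 `N#Cc1ccc(Nc2nc(Oc3c(Br)cc(Br)cc3Br)c3ccccc3n2)cc1` gives 58000 nM. Going by the values given here, the one step between them is a 2.6-fold higher number from compound 1 to compound 2 (0.41 log units; beyond the scatter). Compound 3 `N#Cc1ccc(Nc2nc(Oc3ccc(F)cc3)c3ccccc3n2)cc1` is not yet measured. The change from compound 2 to compound 3 is 4-fluorophenyl in place of 2,4-dibromo-6-methylphenyl on an oxygen on an aromatic ring. The step from compound 1 to compound 2 concerns a single substituent on the very ring that now leaves in full, so it bears on the new step only loosely and supplies no firm direction. Among the compounds with values here, with only this pair to go on, no step beyond the scatter is expected from compound 2 to compound 3, and the estimate is placed between the two measured numbers with a wide range. For compound 3 in this assay the expected value is 100000 nM, ranging from 30000 nM to 300000 nM. This is an expected step of a 1.5-fold lower number from compound 2 to compound 3 (0.18 log units; within the scatter).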

Compound 3, half-maximal cytotoxic concentration: > 351000 nM
Compound 3: only a limit was reported (the forecaster's own chance of this, stated with the estimate: 25%); middle value at least 3.5-fold (0.54 log units) away from the limit.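

Replacing the whole group on the oxygen, rather than a single substituent on it, gives a higher number in this assay from both bromine-bearing compounds: an at least 2.3-fold higher number from compound 2 to compound 3 (0.36 log units; beyond the scatter) and an at least 6.0-fold higher number from compound 1 to compound 3 (0.78 log units; beyond the scatter). As far as these compounds go, compound 3 gives > 351000 nM, which is a limit of the assay and not a number, so the true size of both steps stays unknown. Across the three compounds, fewer bromine atoms on this ring go with a higher number and none goes against this, though methyl and fluorine change along with the bromine.

The compounds shown leave open whether losing bromine, losing methyl or gaining fluorine carries the step from compound 2. They also leave open how a plain phenyl, or a phenyl carrying an amine or a carboxylic acid, would read at this place.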